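Swapping the small aromatic ring on a shared core

The source may report more compounds than this note shows. Statements on the series, on what has been measured and on what is new or still open speak of the compounds shown alone.

Compound 1 `c1cncc(-c2cccc3c2CCC3c2ncc[nH]2)c1` gives > 10000 nM
Compound 2 `Cc1oncc1-c1cccc2c1CCC2c1ncc[nH]1` gives > 10000 nM
Compound 3 `Cn1cc(-c2cccc3c2CCC3c2ncc[nH]2)cn1` gives > 10000 nM

These three compounds share one core and differ only in the small aromatic ring attached to it, and all were tested in a functional assay on CHO cells for agonist activity at Alpha-1D adrenergic receptor (Homo sapiens), read by FLIPR and calcium flux; a lower number here means that less compound is needed, a higher number that more compound is needed for the effect. For compound 3 the reading > 10000 nM is a limit of the assay, not a number. For compound 1 the reading > 10000 nM is likewise a limit. For compound 2 the reading > 10000 nM is a limit as well. Because every value sits at the limit of > 10000 nM in this assay, at which 3 of the 3 values shown sit, none of the steps between them can be sized: a step that the two limits leave unreadable from compound 1 to compound 3, a step that the two limits leave unreadable from compound 2 to compound 3 and a step that the two limits leave unreadable from compound 1 to compound 2 all stay unreadable.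

Compound 4 `c1cc(-c2ncco2)c2c(c1)C(c1ncc[nH]1)CC2` has not yet been measured. It differs from compound 3 by 1,3-oxazol-2-yl in place of 1-methyl-1H-pyrazol-4-yl on an aromatic carbon. The two steps leading into compound 3 are the ones that bear on this change, and both are unreadable, so there is no measured basis for a step in either direction. Three small aromatic rings at this position have all given limits, and a fourth is expected to do the same. The expected step in this assay is a step that the limit leaves unreadable from compound 3 to compound 4, nothing beyond the scatter. Compound 4 is therefore estimated at 15000 nM, between 3000 nM and 60000 nM, most probably reported again as a limit.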

Compound 4, half-maximal effective concentration: 1390 nM
Estimate against measurement, compound 4: 11-fold (1.03 log units) above, outside the stated range (below it).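

At this position on the shared core, a small aromatic ring can give a real reading in this assay: the change to 1,3-oxazol-2-yl brings an at least 7.1-fold lower number from compound 3 to compound 4 (0.85 log units; beyond the scatter) and, measured against the other two rings, an at least 7.1-fold lower number from compound 2 to compound 4 (0.85 log units; beyond the scatter) and an at least 7.1-fold lower number from compound 1 to compound 4 (0.85 log units; beyond the scatter) as well. The leaving 1-methyl-1H-pyrazol-4-yl and the entering 1,3-oxazol-2-yl are both five-membered aromatic rings with 2 hetero atoms and have the same hydrogen-bond donor and acceptor counts, so these shared features do not separate them, and the choice of ring at this position is clearly not neutral in the way the first three compounds suggested. Each step gives only the smallest possible size, and the true gaps could be larger, because the three starting compounds all rest on the same limit: the limit of > 10000 nM in this assay, at which 3 of the 4 values shown sit.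

Going by these compounds, how much further the number can fall at this position remains open, as does which feature of the 1,3-oxazol-2-yl ring matters. A 1,3-thiazol-2-yl ring, with sulfur in place of the oxygen, or a methyl group added to the 1,3-oxazol-2-yl ring would be informative tests of that question.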